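Para-substituent swap on the benzylamide: sulfamoyl for trifluoromethylsulfanyl

The source may hold more compounds than are shown below. What is called first, only, known or untested is meant among the compounds shown, and "the series" means these compounds.

Two compounds of this series have numbers in an assay on HeLa cells with Bile acid receptor (Homo sapiens) as the target, read by a luciferase reporter, with a stated time of 24 h; a lower number here means that less compound is needed, a higher number that more compound is needed for the effect. Compound 1 `CC(C)(C)c1ccc(C(=O)NCc2ccc(S(C)(=O)=O)cc2)cc1` carries a methylsulfonyl group and gives 3800 nM. Compound 2 `CC(C)(C)c1ccc(C(=O)NCc2ccc(SC(F)(F)F)cc2)cc1` carries a (trifluoromethyl)sulfanyl group instead and gives 0.4 nM, the lowest of the two numbers, with a 9500-fold lower number from compound 1 to compound 2 (3.98 log units; beyond the scatter).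

Compound 3 `CC(C)(C)c1ccc(C(=O)NCc2ccc(S(N)(=O)=O)cc2)cc1` is the next member: sulfamoyl in place of (trifluoromethyl)sulfanyl on an aromatic carbon. For the measured compounds named here, the only measured step that bears on this change is the one from compound 1 to compound 2, where the same position was altered and the number moved by a large amount. Sulfamoyl stands structurally closer to the methylsulfonyl of compound 1 than to the (trifluoromethyl)sulfanyl of compound 2, so the step is expected to run in the opposite direction, towards a markedly higher number in this assay, with a size of roughly the same order as that earlier step rather than within the scatter. On that basis compound 3 is expected to give about 3000 nM, with a range from 300 nM to 30000 nM, which means an estimated 7500-fold higher number from compound 2 to compound 3 (3.88 log units; beyond the scatter).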

Compound 3, half-maximal effective concentration: 1400 nM
Estimate against measurement, compound 3: 2.1-fold (0.33 log units) above; the range from low to high includes it.
By their numbers in this assay, from the lowest: compound 2; then compound 3; then compound 1.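

In this assay the move to sulfamoyl gives a 3500-fold higher number from compound 2 to compound 3 (3.54 log units; beyond the scatter) and shows that the large change at this position is not confined to the methylsulfonyl of compound 1: a second sulfonyl-containing group also lies far above compound 2. Within the sulfonyl pair, amino in place of methyl on the sulfonyl sulfur gives a 2.7-fold lower number from compound 1 to compound 3 (0.43 log units; beyond the scatter) and this difference, though beyond the scatter, is modest beside the large step from compound 2. Among these three compounds, the position therefore separates the (trifluoromethyl)sulfanyl of compound 2 sharply from both sulfonyl-containing groups, while the exchange on the sulfonyl sulfur has a much smaller effect on the number.

The compounds shown do not separate the contribution of the fluorine atoms from that of the sulfur-bound oxygen atoms, a question that a methylsulfanyl or a trifluoromethylsulfonyl group at the same position would address directly. They also leave open whether a group without sulfur, such as trifluoromethoxy or a carboxylic acid, would sit near compound 2 or near the sulfonyl pair. No available evidence bears on the origin of these differences.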